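tert-Butyl to 1-hydroxy-1-methylethyl on compound 2

A few compounds are considered here, and "the series" means these few. Any claim that something is new, unique, unknown or untested is made for them only; others in the source may bear on it.

Compound 2 `CC(C)(C)c1cc(Nc2ccc(Cl)cc2Cl)ncc1C(=O)NCC1CCOCC1` gives 23 ug/mL in a physicochemical assay for solubility, at pH 7.4 (a higher number here means a more soluble compound, a lower number a less soluble compound), and sits within the scatter of compound 3 `Cc1cccc(Nc2cc(C3CC3)c(C(=O)NCC3CCOCC3)cn2)c1` at 26 ug/mL on the numbers available. Compound 1 `O=C(NCC1CCOCC1)c1cnc(Nc2cccc(OC(F)(F)F)c2)cc1C1CC1` gives only a limit of < 1 ug/mL in this assay and no number. The change to compound 4 `CC(C)(O)c1cc(Nc2ccc(Cl)cc2Cl)ncc1C(=O)NCC1CCOCC1` is hydroxy in place of methyl on a saturated chain carbon bound to an aromatic carbon and two saturated chain carbons (hydroxy in place of methyl, on a saturated chain carbon bound to an aromatic carbon and two saturated chain carbons). Among the measured compounds shown here, the one measured step, an at least 26-fold higher number from compound 1 to compound 3 (1.41 log units; beyond the scatter) with methyl in place of trifluoromethoxy on an aromatic carbon, is large but lies elsewhere, so it bears only indirectly. A moderate rise, a 3.0-fold higher number from compound 2 to compound 4 (0.48 log units; beyond the scatter) as the expected step, is estimated in this assay and stays smaller than that step. For compound 4 the expected value is 70 ug/mL with an estimated range of 25 ug/mL to 200 ug/mL in this assay.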

Compound 4, solubility: 150 ug/mL
Compound 4: middle estimate off by 2.1-fold (0.33 log units), on the low side; measured number inside the range.
By their numbers in this assay, from the lowest: compounds 2 and 3 (each within the scatter of the next); then compound 4. At a limit, below all of these: compound 1.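

In this assay, hydroxy in place of methyl on the saturated chain carbon bound to an aromatic carbon and two saturated chain carbons gives a 6.5-fold higher number from compound 2 to compound 4 (0.81 log units; beyond the scatter), the only step shown at this position. Among the compounds shown here, the other step, an at least 26-fold higher number from compound 1 to compound 3 (1.41 log units; beyond the scatter), lies on an aromatic carbon, so this is the first sign that the position itself responds to a single-atom change. Nothing measured here accounts for the step.

From the compounds shown here alone, whether a methoxy, an amine or a carboxylic acid on this carbon would behave like hydroxy remains open. Also open, going by these compounds, is whether the step holds with the trifluoromethoxy or methyl aromatic substituent of compound 1 and compound 3.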